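The source may hold more compounds than are shown below. What is called first, only, known or untested is meant among the compounds shown, and "the series" means these compounds.

Measured compounds:
Compound 1, `NC(=O)Nc1sc(-c2ccc(C(=O)N3CCCCC3)cc2)cc1C(=O)N[C@H]1CCCNC1`: 10800 nM
Compound 2, `CS(=O)(=O)Nc1ccc(-c2cc(C(=O)N[C@H]3CCCNC3)c(NC(N)=O)s2)cc1`: "not determined" (no result reported)

For the measured compounds named here, in an assay on isolated protein for inhibition of cyclin-dependent kinase 2-associated protein 1 (Homo sapiens) (a lower number here means a stronger inhibitor, a higher number a weaker inhibitor), compound 1 gives 10800 nM, the only number in this set. For compound 2 this assay gives "not determined" (no result reported), so compound 2 stands nowhere on the numbers: there is no value to place it against compound 1 or to anchor the next step. Compound 3 has the structure `CN(C)C(=O)c1ccc(-c2cc(C(=O)N[C@H]3CCCNC3)c(NC(N)=O)s2)cc1`. It differs from compound 2 in one place: dimethylcarbamoyl in place of methanesulfonamido on an aromatic carbon. With no number for compound 2, no size or direction of this step can be read from data; it may move potency either way or stay within the scatter. The estimate for compound 3 therefore rests on compound 1, whose 10800 nM is the only measured point among these closely built compounds. Compound 3 is expected to give about 10000 nM, with a range from 3000 nM to 40000 nM.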

Compound 3, half-maximal inhibitory concentration: 3700 nM
The estimate for compound 3 lay 2.7-fold (0.43 log units) above the measured number; the range from low to high includes it.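

In this assay, for the compounds shown here, exchanging piperidin-1-yl for dimethylamino on a carbonyl carbon gives the first step that can be read: a 2.9-fold lower number from compound 1 to compound 3 (0.47 log units; beyond the scatter). The ring of the piperidin-1-yl group is therefore not required for inhibition here, as compound 3 has no ring in that group and still gives a lower number, though at 3700 nM it remains a weak inhibitor. The change from methanesulfonamido to dimethylcarbamoyl cannot be read, as compound 2 has no number to compare with.

Nothing measured here explains why the dimethylamino group gives the lower number. From the compounds shown here alone, it remains open how other groups on this carbonyl carbon, such as a pyrrolidine ring, a morpholine ring or an unsubstituted amine, would compare with dimethylamino.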